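Compound 3: an oxadiazole chain replaces a cyclobutyl nitrile

A few compounds are considered here, and "the series" means these few. Any claim that something is new, unique, unknown or untested is made for them only; others in the source may bear on it.

In an ADME assay on MDCKII-LE cells (Canis lupus familiaris) for permeability (on this read-out higher numbers stand for higher permeability and lower numbers for lower permeability), compound 1 `N#C[C@H]1C[C@H](CN([C@H](CCC(F)(F)F)C(N)=O)S(=O)(=O)c2ccc(Cl)cc2)C1` gives 24.9 10^-6 cm/s and compound 2 `C[C@]1(C#N)C[C@H](CN([C@H](CCC(F)(F)F)C(N)=O)S(=O)(=O)c2ccc(Cl)cc2)C1` gives 21.8 10^-6 cm/s, so these two numbers lie within the scatter of each other. Compound 3 `NC(=O)[C@@H](CCC(F)(F)F)N(CCCc1ncon1)S(=O)(=O)c1ccc(Cl)cc1` carries 2-(1,2,4-oxadiazol-3-yl)ethyl in place of 3-cyano-3-methylcyclobutyl on a saturated chain carbon bound to a sulfonamide nitrogen. Among the compounds with values here, the only measured step, a 1.1-fold lower number from compound 1 to compound 2 (0.06 log units; within the scatter), involves a different change, so it offers loose guidance at best. No step beyond the scatter is expected in this assay, and the estimated step is a 1.3-fold lower number from compound 2 to compound 3 (0.11 log units; within the scatter). For compound 3 the expected value is 17 10^-6 cm/s, with an estimated range of 7 10^-6 cm/s to 30 10^-6 cm/s.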

Compound 3, apparent permeability: 31.3 10^-6 cm/s
Estimate against measurement, compound 3: 1.8-fold (0.27 log units) below, outside the stated range (above it).
By their numbers in this assay, from the lowest: compounds 2, 1 and 3 (each within the scatter of the next).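

In this assay, putting 2-(1,2,4-oxadiazol-3-yl)ethyl in place of the cyclobutyl nitriles gives a 1.4-fold higher number from compound 2 to compound 3 (0.16 log units; within the scatter) and a 1.3-fold higher number from compound 1 to compound 3 (0.10 log units; within the scatter). On a saturated chain carbon bound to a sulfonamide nitrogen, then, a four-membered carbon ring with its nitrile can give way to a flexible chain ending in a five-membered aromatic ring without a step beyond the scatter. Nothing shown explains why the read-out holds.
Still open, from the compounds shown here alone, is whether an amine or a carboxylic acid at the end of this chain would hold the number in the same range, and whether a longer chain would.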